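Growth inhibition notes: from compound 2 to compound 3

A few compounds are considered here, and "the series" means these few. Any claim that something is new, unique, unknown or untested is made for them only; others in the source may bear on it.

- compound 1 `C=C1C(=O)O[C@H]2[C@H]1CC/C(COC(=O)N1CCC(F)(F)CC1)=C\CC[C@@]1(C)O[C@@H]21`: 6130 nM
- compound 2 `C=C1C(=O)O[C@H]2[C@H]1CC/C(COC(=O)NCCN1CCCC1)=C\CC[C@@]1(C)O[C@@H]21`: 18000 nM

Among the measured compounds shown here, in a functional assay on SNB-75 cells (Homo sapiens) for inhibition (on this read-out lower numbers stand for stronger inhibition of growth and higher numbers for weaker inhibition of growth), compound 2 stands at 18000 nM as the higher of the two numbers so far. The change to compound 3 `C=C1C(=O)O[C@H]2[C@H]1CC/C(COC(=O)Nc1n[nH]c(SC)n1)=C\CC[C@@]1(C)O[C@@H]21` is 5-(methylsulfanyl)-1H-1,2,4-triazol-3-yl in place of 2-(pyrrolidin-1-yl)ethyl on an amide-type nitrogen with the rest of the structure unchanged. In words, 5-(methylsulfanyl)-1H-1,2,4-triazol-3-yl takes the place of 2-(pyrrolidin-1-yl)ethyl on an amide-type nitrogen.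

For the measured compounds named here, the only measured step is a 2.9-fold higher number from compound 1 to compound 2 (0.47 log units; beyond the scatter) on exchanging 4,4-difluoropiperidin-1-yl for (2-(pyrrolidin-1-yl)ethyl)amino on a carbonyl carbon. Going by the values given here, that step is modest and bears only indirectly, as no measured compound carries the entering group. It does show that a change at this carbonyl carbon can shift the number beyond the scatter. With compound 2 at the top of a two-compound range, a modest move toward lower numbers is expected, nearer to compound 1 at 6130 nM in this series, though the direction is poorly supported. The expected step is a 2.6-fold lower number from compound 2 to compound 3 (0.41 log units; beyond the scatter) on this estimate. For compound 3 an expected value of 7000 nM is estimated, with a range from 1800 nM to 25000 nM as the expected span.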

Compound 3, concentration for 50% growth inhibition: 1710 nM
Compound 3: the middle estimate sits 4.1-fold (0.61 log units) above what was measured, outside the stated range (below it).
By their numbers in this assay, from the lowest: compound 3; then compound 1; then compound 2.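

Notes on the amide-type nitrogen: in this assay the exchange of 2-(pyrrolidin-1-yl)ethyl for 5-(methylsulfanyl)-1H-1,2,4-triazol-3-yl gives an 11-fold lower number from compound 2 to compound 3 (1.02 log units; beyond the scatter) and so exceeds the earlier 2.9-fold higher number from compound 1 to compound 2 (0.47 log units; beyond the scatter) in size, which shows that this position can carry a large change in the read-out and not only a modest one. The new group also goes past the 4,4-difluoropiperidin-1-yl carbamate, with (5-(methylsulfanyl)-1H-1,2,4-triazol-3-yl)amino on the carbonyl carbon giving a 3.6-fold lower number from compound 1 to compound 3 (0.55 log units; beyond the scatter) as a modest step, so the order from the lowest number now runs compound 3, compound 1, compound 2 and the series low point no longer lies with a group that has no aromatic ring. No measurement at hand accounts for the lower number of compound 3.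

The three compounds do not separate the part played by the methylsulfanyl group from that of the triazole ring, since they include no 1H-1,2,4-triazol-3-yl carrying a hydrogen, a methyl or an amine in that place. They also leave open whether a different aromatic ring, such as a phenyl or a pyridine, on the same amide-type nitrogen would follow compound 3 or stay nearer compound 2.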